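The compounds below may be only part of what the source reports. "The series", "measured", "known", "first", "only" and "open" are said of these compounds alone.

The measured compounds and their values in an assay for binding affinity to 5-hydroxytryptamine receptor 1F (Homo sapiens), read by radioligand binding; on this read-out higher numbers stand for weaker inhibition and lower numbers for stronger inhibition:

compound 1, `CCCCCCCC(=O)Nc1ccc2[nH]cc(C3CCN(C)CC3)c2n1`, gives 20 nM
compound 2, `COc1ccccc1C(=O)Nc1ccc2[nH]cc(C3CCN(C)CC3)c2n1`, gives 20 nM
compound 3, `CN1CCC(c2c[nH]c3ccc(NC(=O)c4cccs4)nc23)CC1`, gives 7.1 nM

Compound 1 stands level with compound 2 at the digits shown, and together these two give the highest numbers of the three. The step of no change at the digits printed from compound 1 to compound 2 (within the scatter) is within the scatter, so compound 1 and compound 2 cannot be ordered. The step of a 2.8-fold lower number from compound 1 to compound 3 (0.45 log units; beyond the scatter) is modest but beyond the scatter, and the step of a 2.8-fold lower number from compound 2 to compound 3 (0.45 log units; beyond the scatter) is of the same size, so compound 3 gives the lowest number of the three.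

Compound 4, `CCCCC(=O)Nc1ccc2[nH]cc(C3CCN(C)CC3)c2n1`, has not yet been measured in this assay. It differs from compound 1 in one place: hydrogen in place of propyl on a saturated chain carbon, four bonds along the chain from a carbonyl carbon.

For the measured compounds named here, none of the measured steps bears directly on this change. All three replace the whole group on the carbonyl carbon, heptyl by 2-methoxyphenyl or by thiophen-2-yl, and none alters the length of a saturated chain while keeping the amide in place. What they show is that the acyl group of compound 1 can be exchanged for unrelated groups with either no change or a modest lowering of the number. Going by the values given here, with no step of the same kind to rest on, the expectation for compound 4 is a small step, if any, with a slight lean toward a higher number, estimated as a 1.5-fold higher number from compound 1 to compound 4 (0.18 log units; within the scatter). The estimated value for compound 4 in this assay is 30 nM, within a range from 10 nM to 100 nM.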

Compound 4, inhibition constant: 14 nM
The estimate for compound 4 lay 2.1-fold (0.33 log units) above the measured number, within the range that was stated.
By their numbers in this assay, from the lowest: compounds 3, 4, 1 and 2 (each within the scatter of the next, the first and the last beyond it).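

In this assay, for the compounds shown here, hydrogen in place of propyl is the only step here that keeps a saturated chain on the carbonyl carbon and changes only its length, and it reads a 1.4-fold lower number from compound 1 to compound 4 (0.15 log units; within the scatter), so compound 1 and compound 4 cannot be ordered and the heptyl group can lose its propyl end without a step beyond the scatter. The butyl group of compound 4 also cannot be ordered against either ring-bearing acyl group, with a 1.4-fold lower number from compound 2 to compound 4 (0.15 log units; within the scatter) and a 2.0-fold higher number from compound 3 to compound 4 (0.29 log units; within the scatter), although compound 1 and compound 2 each stand beyond the scatter of compound 3. Nothing measured in this account gives a reason for these steps.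

As far as these compounds go, whether the number holds with a chain shorter than butyl, such as methyl or ethyl, with a longer chain than heptyl, or with a chain carrying an amine or a carboxylic acid remains open. Also open is what a sulfonamide in place of the amide would give, as none of the compounds shown alters that link.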